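The compounds below may be only part of what the source reports. "The series", "measured", "known", "first", "only" and "open" are said of these compounds alone.

Compound 1 `CC(C)Cc1ccc2c(NCCCNCc3ccco3)ccnc2c1` gives 9.47 in a physicochemical assay for acid dissociation. Compound 2 `COc1cccc(CNCCCNc2ccnc3cc(Cc4ccccc4)ccc23)c1O` gives 9.47. Compound 3 `COc1cccc(CNCCCNc2ccnc3cc(Oc4ccc(F)cc4)ccc23)c1O` gives 9.28.

Compound 1 stands level with compound 2 at the digits shown, and the two together sit at the top of the three numbers. Compound 3 lies furthest from compound 1, though the gap between them is within the scatter. Among the measured compounds shown here, the one step measured between neighbouring structures, a number 0.19 log units lower from compound 2 to compound 3 (within the scatter), is itself within the scatter.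

Compound 4 `Fc1ccc(Cc2ccc3c(NCCCNCc4ccco4)ccnc3c2)c(Cl)c1` differs from compound 1 by 2-chloro-4-fluorophenyl in place of isopropyl on a saturated chain carbon bound to an aromatic carbon. For the measured compounds named here, the only measured step that bears on this change, a number 0.19 log units lower from compound 2 to compound 3 (within the scatter), also swaps a group hanging from the shared core and left the acid dissociation constant essentially where it was. On that basis no shift beyond the scatter is expected in this assay. The step expected is a number 0.07 log units lower from compound 1 to compound 4 (within the scatter). Compound 4 is therefore estimated at 9.4, with a range from 9 to 9.8.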

Compound 4, acid dissociation constant: 9.47
The estimate for compound 4 lay 0.07 log units below the measured number; the range from low to high includes it.
By their numbers in this assay, from the lowest: compounds 3, 1, 2 and 4 (each within the scatter of the next).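

In this assay, 2-chloro-4-fluorophenyl in place of isopropyl on a saturated chain carbon bound to an aromatic carbon gives no change at the digits printed from compound 1 to compound 4 (within the scatter), even though 8 heavy atoms replace 3. The earlier step exchanged benzyl for 4-fluorophenoxy, both of which hold a ring, whereas this change brings a six-membered aromatic ring of carbon only, with fluorine and chlorine, to a place that held no ring, and the read-out still shows no shift beyond the scatter. No measurement shown here accounts for this outcome.

The compounds shown leave open whether an amine or a carboxylic acid in this place would move the number. They also leave open whether the same exchange would give a similar result in a compound carrying the side chain of compound 2.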